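Boronic ester ketone series: cyclohexyl ketone analogue of compound 1

The compounds below may be only part of what the source reports. "The series", "measured", "known", "first", "only" and "open" are said of these compounds alone.

The series rests on a shared core carrying a ketone on the pyrrole ring; compound 1 `Cc1ccc(C(=O)c2ccn(-c3ccc4c(c3)B(O)OC4)c2)cc1` bears a 4-methylphenyl group on the carbonyl carbon. In an ADME assay on L929 cells (Mus musculus) for cytotoxicity, read by resazurin assay, with a stated time of 72 h (on this read-out higher numbers stand for weaker inhibition and lower numbers for stronger inhibition), compound 1 gives only a limit, > 10 ug/mL, so no number places it within the set. Compound 2 `CC(=O)OCc1ccc(C(=O)c2ccn(-c3ccc4c(c3)B(O)OC4)c2)cc1` carries acetoxy in place of hydrogen on a saturated chain carbon bound to an aromatic carbon and in this assay compound 2 gives 10 ug/mL. The step of a number no higher from compound 1 to compound 2 (the limit leaves the size open) cannot be sized, because of the limit of > 10 ug/mL in this assay, at which 1 of the 2 values shown sits.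

Compound 3 `O=C(c1ccn(-c2ccc3c(c2)B(O)OC3)c1)C1CCCCC1` differs from compound 1 at another place: cyclohexyl in place of 4-methylphenyl on a carbonyl carbon. Within the data shown here, no measured step touches the carbonyl substituent; the only step recorded concerns the chain carbon on the 4-methylphenyl group, so nothing of comparable kind bears on this change. Both values seen in this assay sit at or beyond the limit, and the expectation for compound 3 is a step of a number no higher from compound 1 to compound 3 (the limit leaves the size open) of no size beyond the scatter. Compound 3 is therefore estimated at 10 ug/mL, with a range from 4 ug/mL to 25 ug/mL, and a fair chance that only a limit is reported again.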

Compound 3, half-maximal inhibitory concentration: > 10 ug/mL
Compound 3 gave a limit, no number (the forecaster's own chance of this, stated with the estimate: 50%); the middle value lies on the limit itself.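

Compound 1 and compound 3 both give only a limit in this assay, so no step can be read between them: the limit of > 10 ug/mL in this assay, at which 2 of the 3 values shown sit.

The compounds shown leave open whether cyclohexyl in place of 4-methylphenyl on a carbonyl carbon changes the value in this assay at all, and in which direction.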